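Aryl substitution on the tetrazole acetamide series: next step

The source may hold more compounds than are shown below. What is called first, only, known or untested is meant among the compounds shown, and "the series" means these compounds.

Measured compounds:
- compound 1, `Cc1cc(NC(=O)Cn2nnc(-c3ccc(F)cc3)n2)n(C2CCCCC2)n1`, 180 nM in an assay on HEK293 cells for activation of Kir3.1/Kir3.2 (Homo sapiens), read by thallium flux; a lower number here means that less compound is needed, a higher number that more compound is needed for the effect
- compound 2, `Cc1cc(NC(=O)Cn2nnc(-c3ccccc3F)n2)n(C2CCCCC2)n1`, 187 nM in this assay
- compound 3, `Cc1cccc(-c2nnn(CC(=O)Nc3cc(C)nn3C3CCCCC3)n2)c1`, 129 nM in this assay

All three share the same core and differ only in the aryl group on the tetrazole. Compound 3 gives the lowest number of the three in this assay, but its margin over the others is within the scatter: a 1.4-fold lower number from compound 1 to compound 3 (0.14 log units; within the scatter) and a 1.4-fold lower number from compound 2 to compound 3 (0.16 log units; within the scatter). Likewise a 1.0-fold higher number from compound 1 to compound 2 (0.02 log units; within the scatter) shows no separation between the two fluorophenyl isomers. Across these three compounds the aryl substituent pattern has not moved the read-out beyond the noise.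

Compound 4, `Cc1cc(NC(=O)Cn2nnc(-c3ccc(Cl)c(C)c3)n2)n(C2CCCCC2)n1`, has not yet been measured. Relative to compound 3 the change is chloro in place of hydrogen on an aromatic carbon; the chloro enters ortho to a methyl group and para to a large group. Within the data shown here, the steps that bear on this are the three aryl variations above, all within the scatter, including the move from a halogen para to the large group in compound 1 to no halogen there in compound 3. The expected step of a 1.2-fold higher number from compound 3 to compound 4 (0.07 log units; within the scatter) is therefore small, with no direction claimed beyond the scatter. Compound 4 is estimated at 150 nM in this assay, with a likely range from 70 nM to 320 nM.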

Compound 4, half-maximal effective concentration: 712 nM
For compound 4 the middle estimate is 4.7-fold (0.68 log units) below the measured one; measured number above the stated range.
By their numbers in this assay, from the lowest: compounds 3, 1 and 2 (each within the scatter of the next); then compound 4.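

In this assay, among these compounds, the chloro entering ortho to a methyl group and para to a large group gives a 5.5-fold higher number from compound 3 to compound 4 (0.74 log units; beyond the scatter) and is the first change in this aryl set to lie beyond the scatter, whereas all three earlier steps lay within it. The 4-chloro-3-methylphenyl group also separates from both fluorophenyl groups, with a 4.0-fold higher number from compound 1 to compound 4 (0.60 log units; beyond the scatter) and with a 3.8-fold higher number from compound 2 to compound 4 (0.58 log units; beyond the scatter) as well, so this aryl position is not indifferent to every substitution, even though the 4-fluorophenyl, 2-fluorophenyl and 3-methylphenyl groups stay within the scatter of one another. No measurement at hand offers an explanation for the size of this step.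

The compounds shown leave open whether the chloro alone carries the step or whether it depends on the methyl group alongside it, a question that a 4-chlorophenyl compound would address. They also leave open how other groups on the same aromatic carbon, such as bromo, methoxy or an amine, would read out against the hydrogen of compound 3 and the chloro of compound 4.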